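A few compounds are considered here, and "the series" means these few. Any claim that something is new, unique, unknown or untested is made for them only; others in the source may bear on it.

Of the compounds shown here, two share one core and have been measured in an assay on isolated protein for inhibition of aldehyde dehydrogenase 1A1 (Homo sapiens), read by spectrophotometry, tested at 10 uM; on this read-out higher numbers stand for more inhibition at the one concentration tested (going by the name of the read-out) and lower numbers for less inhibition. Compound 1 `CC(C)Cn1c(CN2CCN(C(=O)C3CC3)CC2)nc2ccccc21` gives 13.1% in this assay. Compound 2 `Cc1cccc(Cn2c(CN3CCN(C(=O)c4ccc(C(F)(F)F)cc4)CC3)nc3ccccc32)c1` gives 22.9% in this assay, and these two numbers lie within the scatter of each other, so neither number can be called the higher. Compound 3 `Cc1cccc(Cn2c(CN3CCN(C(=O)c4ccco4)CC3)nc3ccccc32)c1` has not yet been measured in this assay. It differs from compound 2 in one place: furan-2-yl in place of 4-(trifluoromethyl)phenyl on a carbonyl carbon. Going by the values given here, no measured pair shows what such a change does here, so any step is expected to stay small, with no clear direction. The step of a number 6.9 percentage points lower from compound 2 to compound 3 (within the scatter) is expected to fall within the scatter. Compound 3 is estimated at 16%, within 2% to 32%.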

Compound 3, a percentage reported as inhibition, at one concentration (the size of the read-out at that concentration, not a potency): 73.2%
Estimate against measurement, compound 3: 57.2 percentage points below; the whole stated range lies below it.
By their numbers in this assay, from the lowest: compounds 1 and 2 (each within the scatter of the next); then compound 3.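

In this assay, the group on the carbonyl carbon proves decisive: furan-2-yl in place of 4-(trifluoromethyl)phenyl gives a number 50.3 percentage points higher from compound 2 to compound 3 (beyond the scatter) in a single change. Compound 1 and compound 2 differ in more than one place, so they could not show how much this one position can matter. No available evidence accounts for the size of this step. Still open, going by these compounds, is whether the gain belongs to furan-2-yl alone or also appears with thiophen-2-yl, pyridin-2-yl or an unsubstituted phenyl on the same carbonyl carbon.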